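A Second Acetyl Removed from the Side Chain

The source may hold more compounds than are shown below. What is called first, only, known or untested is meant among the compounds shown, and "the series" means these compounds.

Compound 1 `C=C/C=C\[C@H](C)[C@H](OC(N)=O)[C@@H](C)[C@H](OC(C)=O)[C@@H](C)C/C(C)=C\[C@H](C)[C@@H](OC(C)=O)[C@@H](C)/C=C\[C@H](C[C@@H]1OC(=O)[C@H](C)[C@@H](OC(C)=O)[C@H]1C)OC(C)=O` is the fully acetylated parent, and in a functional assay on P388 cells (Mus musculus) for cytotoxicity, read by MTT assay, with a stated time of 48 h (a higher number here means a weaker inhibitor, a lower number a stronger inhibitor), compound 1 gives 837 nM. Compound 2 `C=C/C=C\[C@H](C)[C@H](OC(N)=O)[C@@H](C)[C@H](OC(C)=O)[C@@H](C)C/C(C)=C\[C@H](C)[C@@H](O)[C@@H](C)/C=C\[C@H](C[C@@H]1OC(=O)[C@H](C)[C@@H](OC(C)=O)[C@H]1C)OC(C)=O` differs from it by hydrogen in place of acetyl on an oxygen on a saturated carbon. In this assay compound 2 reaches only a limit, > 6920 nM. The measured step of an at least 8.2-fold higher number from compound 1 to compound 2 (0.91 log units; beyond the scatter) is the single one available, and it ends at the limit of > 6920 nM in this assay, at which 1 of the 2 values shown sits. Compound 3 `C=C/C=C\[C@H](C)[C@H](OC(N)=O)[C@@H](C)[C@H](OC(C)=O)[C@@H](C)C/C(C)=C\[C@H](C)[C@@H](O)[C@@H](C)/C=C\[C@@H](O)C[C@@H]1OC(=O)[C@H](C)[C@@H](OC(C)=O)[C@H]1C` differs from compound 2 by hydrogen in place of acetyl on an oxygen on a saturated carbon. Because an at least 8.2-fold higher number from compound 1 to compound 2 (0.91 log units; beyond the scatter) already shows a loss from removing one acetyl, a further loss, or at best no recovery, is expected from removing another. Compound 3 is therefore expected to give about 15000 nM, within 6920 nM to 60000 nM. The expected step that the limit leaves unreadable from compound 2 to compound 3 carries a strong chance that only a limit is reported once more.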

Compound 3, half-maximal inhibitory concentration: 1150 nM
The estimate for compound 3 lay 13-fold (1.12 log units) above the measured number; measured number below the stated range.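

In this assay, the change from acetoxy to hydroxy at this second oxygen gives an at least 6.0-fold lower number from compound 2 to compound 3 (0.77 log units; beyond the scatter). The same exchange of hydrogen for acetyl therefore does not push activity in one direction in this series, since at the first oxygen it gave an at least 8.2-fold higher number from compound 1 to compound 2 (0.91 log units; beyond the scatter), and its outcome depends on where it is made or on what else has already changed. The size of both steps remains a bound: the limit of > 6920 nM in this assay, at which 1 of the 3 values shown sits.

On these data alone, it remains open whether the same acetoxy to hydroxy change at this second oxygen would lower the number when made directly on compound 1, with the first acetyl still in place. As far as these compounds go, it is also open whether a methyl ether or a longer butyryl ester on this oxygen would behave like the hydroxy or like the acetoxy.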